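Replacing the carbamoylbenzyl arm with a fluorophenylethyl group

A few compounds are considered here, and "the series" means these few. Any claim that something is new, unique, unknown or untested is made for them only; others in the source may bear on it.

Compound 1 `Cc1ccc2[nH]c(=O)c(CN(Cc3ccc(OCC(=O)OC(C)(C)C)cc3)Cc3ccc(C(C)(C)C)cc3)cc2c1`: > 10000 nM
Compound 2 `Cc1ccc2[nH]c(=O)c(CN(Cc3ccc(C(N)=O)cc3)Cc3ccc(C(C)(C)C)cc3)cc2c1`: > 5000 nM

In a toxicity assay on MDCK cells (Canis lupus familiaris) for cytotoxicity, read by crystal violet staining, with a stated time of 48 h (on this read-out lower numbers stand for higher toxicity in this test and higher numbers for lower toxicity in this test), compound 1 gives only a limit, > 10000 nM. Compound 2 likewise gives only a limit, > 5000 nM. The step that the two limits leave unreadable from compound 1 to compound 2 therefore has no readable size, because both values sit at limits (the limit of > 10000 nM in this assay, at which 1 of the 2 values shown sits, and (the limit of > 5000 nM in this assay, at which 1 of the 2 values shown sits)). Compound 2 thus stands at a limit of this assay rather than at a number.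

Compound 3 `Cc1ccc2[nH]c(=O)c(CN(Cc3ccc(C(C)(C)C)cc3)[C@H](C)c3ccc(F)cc3)cc2c1` differs from compound 2 by 1-(4-fluorophenyl)ethyl in place of 4-carbamoylbenzyl on an amine nitrogen. Within the data shown here, no measured step bears on this change, and the single measured step offers no size to carry over, so the expectation rests on compound 2 staying at its limit. Compound 3 is estimated at 10000 nM, with a range from 3000 nM to 30000 nM. The expected step is a step that the limit leaves unreadable from compound 2 to compound 3, which is not read as a change beyond the scatter.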

Compound 3, half-maximal cytotoxic concentration: > 5000 nM
Compound 3 ended at the assay's limit; the forecaster's own chance of this, stated with the estimate: 65%; the middle value is on the limit's open side.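

In this assay compound 3 gives only a limit, > 5000 nM. Compound 2 also stands at a limit, so no step can be read between compound 2 and compound 3. The compounds shown leave open whether 1-(4-fluorophenyl)ethyl and 4-carbamoylbenzyl differ at all in this assay.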